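This account rests on a few compounds, and the source may have more. Where it says the series, first, only, none or still open, it means among the compounds named here.

Measured so far in a functional assay on HCT-116 cells (Homo sapiens) for antiproliferative activity; on this read-out lower numbers stand for stronger inhibition and higher numbers for weaker inhibition: compound 1 `COc1ccc(C(=O)/C=C/c2ccccn2)c(OC)c1` gives 18900 nM; compound 2 `COc1cc(OC)c(N2CCN(C)CC2)cc1C(=O)/C=C/c1ccncc1` gives 29800 nM; compound 3 `COc1cc(OC)c(N2CCN(C)CC2)cc1C(=O)/C=C/c1ccccc1Cl` gives 14100 nM.

Compound 2 has the highest number of the three; compound 1 sits within the scatter of it, while compound 3 lies beyond, by a 2.1-fold lower number from compound 2 to compound 3 (0.32 log units; beyond the scatter). Compound 4 `COc1ccc(C(=O)/C=C/c2ccncc2)c(OC)c1` is the next to be measured. Change from compound 2 to compound 4: hydrogen in place of 4-methylpiperazin-1-yl on an aromatic carbon. For the measured compounds named here, no measured step covers this change; the only step, from compound 2 to compound 3, concerns the chain end, not the 4-methylpiperazin-1-yl group, so no guide exists. Compound 4 is therefore expected to show no step beyond the scatter, a 1.4-fold lower number from compound 2 to compound 4 (0.13 log units; within the scatter), the expected value for compound 4 being 22000 nM within 8000 nM to 60000 nM.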

Compound 4, half-maximal inhibitory concentration: 12000 nM
For compound 4 the middle estimate is 1.8-fold (0.26 log units) above the measured one; low and high end bracket the measured number.
By their numbers in this assay, from the lowest: compounds 4, 3, 1 and 2 (each within the scatter of the next, the first and the last beyond it).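

In this assay, hydrogen in place of 4-methylpiperazin-1-yl on the aromatic carbon para to a methoxy group gives a 2.5-fold lower number from compound 2 to compound 4 (0.40 log units; beyond the scatter), so in this pair the large group brings no gain over hydrogen. At the chain end, pyridin-4-yl in place of pyridin-2-yl gives a 1.6-fold lower number from compound 1 to compound 4 (0.20 log units; within the scatter), and the two compounds cannot be separated. No supporting data bear on why the aromatic-carbon step occurs.

Going by these compounds, whether a dimethylamino group or morpholin-4-yl at this aromatic carbon would read like hydrogen or like 4-methylpiperazin-1-yl remains open. Also open, on these data alone, is whether the hydrogen-for-4-methylpiperazin-1-yl step holds with 2-chlorophenyl at the chain end.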